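Tert-butyl to trifluoromethyl on an inactive urea

The source may hold more compounds than are shown below. What is called first, only, known or untested is meant among the compounds shown, and "the series" means these compounds.

Two piperazine ureas have been examined in an assay on HEK293 cells for inhibition of transient receptor potential cation channel subfamily V member 1 (Homo sapiens), read by FLIPR; a lower number here means a stronger inhibitor, a higher number a weaker inhibitor. Compound 1 `O=C(Nc1ccc(OC(F)(F)F)cc1)N1CCN(c2ccc(-c3ccccc3)nn2)CC1` gives no number there, only the limit > 10000 nM in this assay. Compound 2 `CC(C)(C)c1ccc(NC(=O)N2CCN(c3nncc4ccccc34)CC2)cc1` likewise yields only the limit > 10000 nM. Among the measured compounds shown here, compound 2 thus stands, together with compound 1, at the limit of > 10000 nM in this assay, at which 2 of the 2 values shown sit, and no measured step joins the two, so all that is known of compound 2 is that it sits at the edge of what this assay can report. Compound 3 `O=C(Nc1ccc(C(F)(F)F)cc1)N1CCN(c2nncc3ccccc23)CC1` keeps the core of compound 2 and differs in a single place: trifluoromethyl in place of tert-butyl on an aromatic carbon. For the measured compounds named here, no measured pair shows this exchange. The step of a number no higher from compound 2 to compound 3 (the limit leaves the size open) is expected to stay within the scatter, with no clear direction. Compound 3 is therefore estimated at 10000 nM, between 3000 nM and 30000 nM, most probably reported again as a limit rather than a number.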

Compound 3, half-maximal inhibitory concentration: > 10000 nM
Compound 3: only a limit was reported; the forecaster's own chance of this, stated with the estimate: 70%; the middle value sits exactly at the limit.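

Compound 2 and compound 3 both yield only a limit, so the step from one to the other cannot be read. The compounds shown leave open what number any of them would give, and whether trifluoromethyl in place of tert-butyl changes it at all: the limit of > 10000 nM in this assay, at which 3 of the 3 values shown sit.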